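The source may hold more compounds than are shown below. What is called first, only, known or untested is meant among the compounds shown, and "the series" means these compounds.

Measured in a functional assay on SW-620 cells (Homo sapiens) for antiproliferative activity, read by MTT assay, with a stated time of 72 h; on this read-out higher numbers stand for weaker inhibition and lower numbers for stronger inhibition:

compound 1 `CC(=O)OCC(CCn1cc(C#CCc2ccccc2)c(=O)n(C(=O)c2ccccc2)c1=O)COC(C)=O` gives 36400 nM.
compound 2 `CC(=O)OCC(CCn1cc(C#CC2CC2)c(=O)n(C(=O)c2ccccc2)c1=O)COC(C)=O` reaches only a limit of the assay, > 100000 nM.
compound 3 `O=c1[nH]c(=O)n(CCC(CO)CO)cc1C#CCc1ccccc1` gives 72400 nM.

Compound 1 and compound 2 differ by cyclopropyl in place of benzyl on a triple-bonded carbon. The step is an at least 2.7-fold higher number from compound 1 to compound 2 (0.43 log units; beyond the scatter); its true size is open because compound 2 sits at the limit of > 100000 nM in this assay, at which 1 of the 3 values shown sits. Compound 3 carries a different core from compound 1; how the two cores differ is not broken down here. The values of compound 3 and compound 1 lie within the usual scatter of each other, so no order between them is claimed.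

Compound 4 `O=c1[nH]c(=O)n(CCC(CO)CO)cc1C#CC1CC1` is not yet measured. It differs from compound 3 by cyclopropyl in place of benzyl on a triple-bonded carbon, the same change at the same place as between compound 1 and compound 2. The step from compound 3 to compound 4 is expected to be a 2.8-fold higher number from compound 3 to compound 4 (0.44 log units; beyond the scatter), resting on an at least 2.7-fold higher number from compound 1 to compound 2 (0.43 log units; beyond the scatter) and on compound 3 starting from 72400 nM, already a weak number. Compound 4 is therefore estimated at 200000 nM, with a plausible range from 100000 nM to 500000 nM, and a good chance that only a limit is reported.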

Compound 4, half-maximal inhibitory concentration: > 100000 nM
Compound 4: a limit, no number (the forecaster's own chance of this, stated with the estimate: 75%); the middle value is on the limit's open side.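

In this assay compound 4 reaches only a limit of the assay, > 100000 nM. Cyclopropyl in place of benzyl on a triple-bonded carbon gives an at least 1.3-fold higher number from compound 3 to compound 4 (0.14 log units; that floor lies within the scatter), so nothing on this core goes against the step seen on the core of compound 1, yet this floor alone does not establish a step on this core: the same change on two cores in this assay, an at least 2.7-fold higher number (0.43 log units; beyond the scatter) from compound 1 to compound 2 and an at least 1.3-fold higher number (0.14 log units; that floor lies within the scatter) from compound 3 to compound 4; the limit leaves it open whether they differ Neither step has a known true size, so the data show no more than a result compatible with carrying the change across the two cores, and they show neither equal nor unequal steps: the limit of > 100000 nM in this assay, at which 2 of the 4 values shown sit.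

The compounds shown leave open how a group other than benzyl or cyclopropyl, such as a longer alkyl chain or an amine-bearing chain, would behave on the triple-bonded carbon. They also leave open whether such a group would give readable numbers on both cores, which would allow the size of a step to be compared from one core to the other.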